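Cyclohexyl to substituted phenyl on the ether oxygen

The compounds below may be only part of what the source reports. "The series", "measured", "known", "first", "only" and "open" are said of these compounds alone.

Measured in an ADME assay on MRC5 cells (Homo sapiens) for cytotoxicity, read by fluorescence and resazurin assay, with a stated time of 3 days; a lower number here means a stronger inhibitor, a higher number a weaker inhibitor:
- compound 1 `Cc1cn(C2CCN(Cc3cccc(Oc4cccc(C(F)(F)F)c4)c3)CC2)c(=O)[nH]c1=O`: 12400 nM
- compound 2 `Cc1cn(C2CCN(Cc3cccc(OC4CCCCC4)c3)CC2)c(=O)[nH]c1=O`: 23600 nM

Among the measured compounds shown here, compound 2 stands level with the only other measured compound, and the one measured step is a 1.9-fold higher number from compound 1 to compound 2 (0.28 log units; within the scatter). Compound 3 `Cc1cn(C2CCN(Cc3cccc(Oc4ccc(Cl)c(C(F)(F)F)c4)c3)CC2)c(=O)[nH]c1=O` differs from compound 2 as follows: 4-chloro-3-(trifluoromethyl)phenyl in place of cyclohexyl on an oxygen on an aromatic ring. That measured step changes the same place, so no step beyond the scatter is expected in this assay. From the compounds shown here alone, compound 1 at 12400 nM is the closest guide, although the 4-chloro-3-(trifluoromethyl)phenyl group itself is untested. The expected change is a 1.8-fold lower number from compound 2 to compound 3 (0.26 log units; within the scatter). Compound 3 is estimated at 13000 nM, with an expected range from 6000 nM to 27000 nM.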

Compound 3, half-maximal inhibitory concentration: 5280 nM
The estimate for compound 3 lay 2.5-fold (0.39 log units) above the measured number; the whole stated range lies above it.
By their numbers in this assay, from the lowest: compound 3; then compounds 1 and 2 (each within the scatter of the next).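

In this assay, replacing cyclohexyl with 4-chloro-3-(trifluoromethyl)phenyl on this oxygen gives a 4.5-fold lower number from compound 2 to compound 3 (0.65 log units; beyond the scatter), so a change at this position can move the number beyond the scatter. Chloro in place of hydrogen on an aromatic carbon gives a 2.3-fold lower number from compound 1 to compound 3 (0.37 log units; beyond the scatter), which shows that this single addition to the aromatic ring registers in this assay. No evidence at hand bears on the cause of either step.

From the compounds shown here alone, whether the chloro step would carry over to other groups on this oxygen remains open. So does the outcome with bromo, methoxy or an amine in the chloro place, or with chloro alone and no trifluoromethyl.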